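Aryl amide variation on a shared core: next member

The source may hold more compounds than are shown below. What is called first, only, known or untested is meant among the compounds shown, and "the series" means these compounds.

Measured so far in a functional assay on CHO cells for antagonist activity at Orexin/Hypocretin receptor type 1 (Homo sapiens), read by FLIPR and calcium flux; on this read-out lower numbers stand for stronger inhibition and higher numbers for weaker inhibition:
compound 1 `Cc1ccc(C)c(NC(=O)CSc2nnc(-c3ccoc3C)n2Cc2ccco2)c1`, reported as a limit of the assay: > 15800 nM
compound 2 `Cc1ccc(NC(=O)CSc2nnc(-c3ccoc3C)n2Cc2ccco2)cc1`, reported as a limit: > 15800 nM
compound 3 `Cc1occc1-c1nnc(SCC(=O)Nc2cccc(F)c2)n1Cc1ccco1`, reported as a limit: > 15800 nM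

Compound 3 thus stands only at a limit in this assay, as do the other two values shown, all of them at the limit of > 15800 nM in this assay, at which 3 of the 3 values shown sit. Compound 4 `Cc1occc1-c1nnc(SCC(=O)Nc2ccc(Cl)cc2)n1Cc1ccco1` differs from compound 3 by 4-chlorophenyl in place of 3-fluorophenyl on an amide-type nitrogen. The measured steps that touch this position, a step that the two limits leave unreadable from compound 1 to compound 2, a step that the two limits leave unreadable from compound 1 to compound 3 and a step that the two limits leave unreadable from compound 2 to compound 3, are all left unreadable by the limits, so no size for a change on this nitrogen can be taken from them. No step beyond the scatter is expected, and the step is estimated as a step that the limit leaves unreadable from compound 3 to compound 4. Compound 4 is therefore expected at about 20000 nM, within a range from 8000 nM to 50000 nM, most likely reported again as a limit.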

Compound 4, inhibition constant: 2000 nM
Beside the measured number, compound 4's estimate is 10-fold (1.00 log units) above it; measured number below the stated range.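

In this assay, the amide-type nitrogen now shows a readable response: 4-chlorophenyl in place of 3-fluorophenyl gives an at least 7.9-fold lower number from compound 3 to compound 4 (0.89 log units; beyond the scatter), chloro in place of methyl on an aromatic carbon gives an at least 7.9-fold lower number from compound 2 to compound 4 (0.89 log units; beyond the scatter), and 4-chlorophenyl in place of 2,5-dimethylphenyl gives an at least 7.9-fold lower number from compound 1 to compound 4 (0.89 log units; beyond the scatter). A change at this one position is thus enough to bring the shared core to a measured number. Compound 4 alone has such a number, while the other compounds remain at a limit: the limit of > 15800 nM in this assay, at which 3 of the 4 values shown sit.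

As far as these compounds go, the full size of these steps stays open. So does whether 4-bromophenyl or 4-methoxyphenyl on this nitrogen would give a lower number than 4-chlorophenyl.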